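The compounds below may be only part of what the source reports. "The series", "measured", "known", "first", "only" and "open" are said of these compounds alone.

Measured compounds:

- compound 1 `COc1cc2c(=O)c(C(=O)c3ccc(C)cc3)cn(Cc3ccc(N)cc3)c2cc1OC`: "not active" (no number reported)
- compound 2 `COc1cc2c(=O)c(C(=O)c3ccc(C)cc3)cn(CC3CCCCC3)c2cc1OC`: 22000 nM
- compound 3 `COc1cc2c(=O)c(C(=O)OCc3cccc(C)c3)cn(Cc3ccc(C(F)(F)F)cc3F)c2cc1OC`: 7300 nM

In an ADME assay on Huh-7 cells (Homo sapiens) for cytotoxicity (on this read-out higher numbers stand for weaker inhibition of growth and lower numbers for stronger inhibition of growth), compound 1 is reported as "not active" (no number reported) with no number attached. Compound 2 gives 22000 nM in this assay, and compound 3 gives 7300 nM, which is the lowest of the two numbers obtained so far; compound 2 lies beyond the scatter from it, with a higher number. Among the compounds with values here, no single-change pair among the measured compounds exists, so no measured step is available to lean on.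

Compound 4 `COc1cc2c(=O)c(C(=O)OCc3ccc(C)cc3)cn(Cc3ccc(C(F)(F)F)cc3F)c2cc1OC` is compound 3 with the methyl group moved on the ring of the ester: 4-methylphenyl in place of 3-methylphenyl on a saturated chain carbon bound to an oxygen next to a carbonyl group. The atoms are the same and only the joining differs. Within the data shown here, nothing among the measured compounds shows what such a change does in this assay.

Among the measured compounds shown here, with no measured step to guide it, the expectation for compound 4 in this assay is a number close to that of compound 3, with the step from compound 3 to compound 4 estimated as no change at the digits printed from compound 3 to compound 4 (within the scatter), none beyond the scatter in either direction. For compound 4 the estimate in this assay is 7300 nM, with a range from 3000 nM to 18000 nM.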

Compound 4, concentration for 50% growth inhibition: 20000 nM
The estimate for compound 4 lay 2.7-fold (0.44 log units) below the measured number; measured number outside the range, above it.
By their numbers in this assay, from the lowest: compound 3; then compounds 4 and 2 (each within the scatter of the next).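

In this assay, the move to 4-methylphenyl in place of 3-methylphenyl on a saturated chain carbon bound to an oxygen next to a carbonyl group gives a 2.7-fold higher number from compound 3 to compound 4 (0.44 log units; beyond the scatter) and is a modest step. Within the data shown here, this is the first pair that differs in one place, since compounds 1, 2 and 3 differ from one another in more than one place and could not isolate any single change. It shows that, with the rest of compound 3 held fixed, the read-out responds to where the methyl sits on this ring of the ester, although the leaving and entering groups have the same atoms and the same counts, and nothing measured here accounts for the size or direction of the step.

On these data alone, it remains open whether a methoxy group, an amine or a carboxylic acid in place of the methyl would show the same dependence on ring position. As far as these compounds go, it is also open whether the same move would give a similar step in compounds with the ketone link of compound 2 or with cyclohexylmethyl on the ring nitrogen of the shared core.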